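From 4-Methoxyphenyl to 3,4-Difluorophenyl on the Carbonyl Carbon

The source may hold more compounds than are shown below. What is called first, only, known or untested is meant among the compounds shown, and "the series" means these compounds.

Of the compounds shown here, three built on one shared core have been measured in a functional assay on 786-0 cells (Homo sapiens) for cytotoxicity, read by sulforhodamine B assay, with a stated time of 48 h, tested at 0.1 uM; on this read-out higher numbers stand for a weaker effect at the one concentration tested and lower numbers for a stronger effect. Compound 1 `COc1cc(-c2cc(/C=C/C(=O)c3ccc(Cl)c(Cl)c3)[nH]n2)cc(OC)c1OC` gives 94%, compound 2 `COc1ccc(C(=O)/C=C/c2cc(-c3cc(OC)c(OC)c(OC)c3)n[nH]2)cc1` gives 96%, and compound 3 `COc1cc(C(=O)/C=C/c2cc(-c3cc(OC)c(OC)c(OC)c3)n[nH]2)cc(OC)c1OC` gives 105%. Compound 2 stands between the other two on these numbers: its nearest neighbour is compound 1 and its furthest is compound 3, and both gaps lie within the scatter, so the three values cannot be told apart. For the measured compounds named here, the single one-place step among them, a number 2 percentage points higher from compound 1 to compound 2 (within the scatter), came from an exchange on the carbonyl carbon and stayed within the scatter.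

Compound 4 `COc1cc(-c2cc(/C=C/C(=O)c3ccc(F)c(F)c3)[nH]n2)cc(OC)c1OC` has not yet been measured. It differs from compound 2 in 3,4-difluorophenyl in place of 4-methoxyphenyl on a carbonyl carbon. Going by the values given here, only one measured step bears on this change: a number 2 percentage points higher from compound 1 to compound 2 (within the scatter), which also exchanged 3,4-dichlorophenyl against 4-methoxyphenyl on a carbonyl carbon and did not move the read-out beyond the scatter. Compound 4 is therefore expected to show no step beyond the scatter in this assay, the estimated change being no change at the digits printed from compound 2 to compound 4 (within the scatter). Compound 4 is estimated at 96%, with a range from 86% to 106%.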

Compound 4, a percentage reported as activity, at one concentration (the size of the read-out at that concentration, not a potency): 95%
For compound 4 the middle estimate is 1 percentage points above the measured one, and the stated range covers the measured number.
By their numbers in this assay, from the lowest: compounds 1, 4, 2 and 3 (each within the scatter of the next, the first and the last beyond it).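

In this assay, the exchange of 4-methoxyphenyl for 3,4-difluorophenyl on the carbonyl carbon gave a number 1 percentage points lower from compound 2 to compound 4 (within the scatter), and the exchange of 3,4-dichlorophenyl for 3,4-difluorophenyl at the same place gave a number 1 percentage points higher from compound 1 to compound 4 (within the scatter). For the compounds shown here, the earlier compounds offered only one exchange at this position, whereas three groups can now be compared there, and neither the swap between the two halogenated phenyl groups nor the swap from the methoxy-bearing ring to a fluorinated one moves the read-out beyond the scatter. No measurement is at hand that could explain why these groups cannot be told apart at this position.

The compounds shown leave open whether a phenyl ring carrying an amine or a carboxylic acid, or a saturated alkyl chain in place of the aromatic ring on the carbonyl carbon, would shift the read-out beyond the scatter. They also leave open whether 3,4-difluorophenyl, 3,4-dichlorophenyl and 4-methoxyphenyl would still be indistinguishable at a concentration other than the single one tested here.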